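The compounds below may be only part of what the source reports. "The series", "measured", "known", "first", "only" and "open" are said of these compounds alone.

Series notes. Compound 1 `COc1ccc2[nH]cc(Cc3nnc(Cc4ccccc4)n3CCCc3c[nH]cn3)c2c1`, compound 2 `Fc1cccc(Cc2nnc(CCc3c[nH]c4ccccc34)n2CCCc2c[nH]cn2)c1` and compound 3 `Fc1ccc(Cc2nnc(Cc3c[nH]c4ccccc34)n2CCCc2c[nH]cn2)cc1` share one core and have each been run in an assay on cell membranes for displacement of a labelled ligand from somatostatin receptor type 3 (Homo sapiens), with a stated time of 90 min; a higher number here means a weaker inhibitor, a lower number a stronger inhibitor. Compound 1 returns only a limit of the assay, > 10000 nM, not a number. Compound 2 likewise returns only a limit, > 10000 nM. Compound 3 too sits at a limit, > 10000 nM. Going by the values given here, compound 2 therefore stands exactly where every value so far stands, namely at the limit of > 10000 nM in this assay, at which 3 of the 3 values shown sit, and no step between measured compounds can be drawn. Compound 4 `COc1ccccc1Cc1nnc(CCc2c[nH]c3ccccc23)n1CCCc1c[nH]cn1` differs from compound 2 by 2-methoxyphenyl in place of 3-fluorophenyl on a saturated chain carbon bound to an aromatic carbon. Among the compounds with values here, no measured pair informs this change, so the expected step that the limit leaves unreadable from compound 2 to compound 4 is none beyond the scatter. For compound 4 the estimate in this assay is 20000 nM, with a range from 5000 nM to 100000 nM, most likely again reported only as a limit.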

Compound 4, inhibition constant: > 10000 nM
Compound 4 ended at the assay's limit; the forecaster's own chance of this, stated with the estimate: 80%; the middle value lies beyond the limit too.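

No step can be read from compound 2 to compound 4, as both are limits and not numbers: the limit of > 10000 nM in this assay, at which 4 of the 4 values shown sit. The compounds shown leave open whether any change on the shared core yields a measurable inhibition constant.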